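A few compounds are considered here, and "the series" means these few. Any claim that something is new, unique, unknown or untested is made for them only; others in the source may bear on it.

The series shares the core of compound 1 `CN(C)CCn1cnnc1-c1cc(Oc2ccc(NC(=O)N/N=C/c3c(O)ccc4ccccc34)cc2F)ccn1`, and the three analogues measured so far vary only the aryl group on the carbon with a double bond to nitrogen. In a functional assay on A549 cells (Homo sapiens) for cytotoxicity, read by MTT assay, with a stated time of 72 h (a higher number here means a weaker inhibitor, a lower number a stronger inhibitor), compound 1 gives 880 nM. Compound 2 `CN(C)CCn1cnnc1-c1cc(Oc2ccc(NC(=O)N/N=C/c3ccccc3O[N+](=O)[O-])cc2F)ccn1` gives 1200 nM in this assay, and compound 3 `Cc1cc(/C=N/NC(=O)Nc2ccc(Oc3ccnc(-c4nncn4CCN(C)C)c3)c(F)c2)cc(C)c1O` gives 1640 nM. Compound 3 holds the highest of the three numbers, yet every step separating it from the others stays within the scatter: a 1.9-fold higher number from compound 1 to compound 3 (0.27 log units; within the scatter) and a 1.4-fold higher number from compound 2 to compound 3 (0.14 log units; within the scatter), while a 1.4-fold higher number from compound 1 to compound 2 (0.13 log units; within the scatter). Within the data shown here, nothing measured so far separates the three aryl groups from one another.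

Compound 4 `CN(C)CCn1cnnc1-c1cc(Oc2ccc(NC(=O)N/N=C/c3ccc(Cl)cc3Cl)cc2F)ccn1` is not yet measured. It differs from compound 3 in one place: 2,4-dichlorophenyl in place of 4-hydroxy-3,5-dimethylphenyl on a carbon with a double bond to nitrogen. All three measured steps change this same position, and each of them lies within the scatter, so the expectation for this assay is a step no larger than the scatter, with no direction set by the data. As far as these compounds go, the loss of the hydroxyl donor is untested and widens the range rather than shifting the middle. Compound 4 is therefore expected to give about 1500 nM in this assay, with a range from 500 nM to 4500 nM, corresponding to an estimated step of a 1.1-fold lower number from compound 3 to compound 4 (0.04 log units; within the scatter).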

Compound 4, half-maximal inhibitory concentration: 810 nM
The estimate for compound 4 lay 1.9-fold (0.27 log units) above the measured number; measured number inside the range.
By their numbers in this assay, from the lowest: compounds 4, 1, 2 and 3 (each within the scatter of the next, the first and the last beyond it).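

In this assay, among these compounds, the change to 2,4-dichlorophenyl gives a 2.0-fold lower number from compound 3 to compound 4 (0.31 log units; beyond the scatter), the first step at this position to pass the scatter, though only modestly, so this position is not entirely flat. The other two steps, a 1.5-fold lower number from compound 2 to compound 4 (0.17 log units; within the scatter) and a 1.1-fold lower number from compound 1 to compound 4 (0.04 log units; within the scatter), stay within the scatter, so the separation holds only against compound 3, and an entering group with no hydrogen-bond donor keeps compound 4 level with compound 1 and compound 2. The data offer no measured basis for explaining the step from the 4-hydroxy-3,5-dimethylphenyl group to the 2,4-dichlorophenyl group.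

The compounds shown leave open whether both chlorine atoms are needed for the separation from compound 3, a question that a monochlorophenyl or unsubstituted phenyl group would address. They also leave open how this position responds to groups outside the aryl types seen here, such as a phenyl carrying an amine or a carboxylic acid, or a longer alkyl chain in place of the aryl ring.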